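The source may hold more compounds than are shown below. What is called first, only, known or untested is meant among the compounds shown, and "the series" means these compounds.

Measured compounds in an ADME assay on J774.A1 cells (Mus musculus) for cytotoxicity, read by MTT assay; on this read-out higher numbers stand for lower toxicity in this test and lower numbers for higher toxicity in this test:
- Compound 1, `CC(CCn1ccnc1)Oc1ccc([N+](=O)[O-])cc1F`, gives 15 ug/mL.
- Compound 3, `O=[N+]([O-])c1ccc(OC(CCn2ccnc2)COc2ccccc2)c(F)c1`, gives 29.6 ug/mL.
- Compound 2, `CC(CCn1ccnc1)Oc1ccccc1[N+](=O)[O-]`, reaches only a limit of this assay, > 100 ug/mL.

Compound 1 and compound 3 share a core and differ in one place: phenoxy in place of hydrogen on a saturated chain carbon, two bonds along the chain from an oxygen on an aromatic ring. Across that change the read-out moves a 2.0-fold higher number from compound 1 to compound 3 (0.30 log units; within the scatter), so the phenoxy group leaves the cytotoxicity of this pair essentially where it was.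

Compound 2 carries a different core; the difference between the two cores is not broken down here. Compound 2 stands at the limit of > 100 ug/mL in this assay, at which 1 of the 3 values shown sits, so only the limit is known for it and no number can be compared against compound 1 or compound 3.

Compound 4, `O=[N+]([O-])c1ccccc1OC(CCn1ccnc1)COc1ccccc1`, is not yet measured. It differs from compound 2 by the same change that turns compound 1 into compound 3: phenoxy in place of hydrogen on a saturated chain carbon, two bonds along the chain from an oxygen on an aromatic ring. Among the measured compounds shown here, the single measured instance of this change gave a step within the scatter, a 2.0-fold higher number from compound 1 to compound 3 (0.30 log units; within the scatter), and compound 2 itself sits at the limit, so compound 4 is expected to stay near that limit, with an expected step of a number no higher from compound 2 to compound 4 (the limit leaves the size open) from compound 2. The estimate for compound 4 in this assay is 100 ug/mL, with a likely range from 40 ug/mL to 250 ug/mL, and a fair chance that only a limit is again reported.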

Compound 4, half-maximal cytotoxic concentration: 36.2 ug/mL
For compound 4 the middle estimate is 2.8-fold (0.44 log units) above the measured one; the measured number lies below the stated range.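

Carrying phenoxy in place of hydrogen onto the core of compound 2, on a saturated chain carbon, two bonds along the chain from an oxygen on an aromatic ring, gives an at least 2.7-fold lower number from compound 2 to compound 4 (0.44 log units; beyond the scatter) in this assay, and this size is only a lower bound, since the starting point of this step is a limit of the assay rather than a number. Set beside the same change on the core of compound 1, the step does not transfer from one core to the other: the same change on two cores in this assay, a 2.0-fold higher number (0.30 log units; within the scatter) from compound 1 to compound 3 and an at least 2.7-fold lower number (0.44 log units; beyond the scatter) from compound 2 to compound 4, at least 5.4-fold (0.73 log units) apart, beyond the scatter of two such steps This shows that, in these two pairs, the outcome of the change in this assay differs with the core, but two pairs do not show which feature of the cores accounts for the difference, nor how the change would behave on any further core.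

The compounds shown leave open how far the step on the core of compound 2 actually runs, and whether the split between the two cores also appears with other groups at this place. A phenyl group, a longer chain or an amine in place of phenoxy would test whether the split is specific to phenoxy.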